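The source may report more compounds than this note shows. Statements on the series, on what has been measured and on what is new or still open speak of the compounds shown alone.

Measured so far:
- compound 1 `CO/N=C1\CC[C@@]2(C)[C@H](CC[C@H]3[C@@H]4CC[C@@]5(CC(C)=C4C[C@@H]32)O[C@@H]2C[C@H](C)CN[C@H]2[C@H]5C)C1`: 0.917 h
- compound 2 `CC1=C2C[C@H]3[C@@H](CC[C@@H]4C[C@H](n5ccnn5)CC[C@@]43C)[C@@H]2CC[C@@]2(C1)O[C@@H]1C[C@H](C)CN[C@H]1[C@H]2C`: 0.667 h

In an in vitro ADME assay on microsomes from liver (Homo sapiens) for metabolic stability, tested at 500 nM (a lower number here means that the compound disappears faster, a higher number that the compound lasts longer), compound 2 gives 0.667 h and compound 1 gives 0.917 h. These two values lie within the usual scatter of each other, so neither can be placed ahead of the other. Among the measured compounds shown here, they are also the only two measurements available.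

The next compound is compound 3 `CC1=C2C[C@H]3[C@@H](CC[C@@H]4C[C@@H](n5ccnn5)CC[C@@]43C)[C@@H]2CC[C@@]2(C1)O[C@@H]1C[C@H](C)CN[C@H]1[C@H]2C`, which is still unmeasured. Relative to compound 2 the change is confined to configuration: the two compounds have the same atoms and bonds and differ only in configuration as drawn: 1 of 11 stereo elements differ; a stereocentre at a saturated ring carbon is drawn R in compound 2 and S in compound 3. For the measured compounds named here, no measured pair isolates a change of this kind, so there is no observed step to carry over.

The expectation therefore rests on compound 2 at 0.667 h, the closest measured structure. The expected outcome for a 1.0-fold higher number from compound 2 to compound 3 (0.02 log units; within the scatter) is no change beyond the scatter in this assay, with neither direction favoured. For compound 3 the estimated half-life is 0.7 h, with an expected range from 0.35 h to 1.4 h.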

Compound 3, half-life: 1.17 h
For compound 3 the middle estimate is 1.7-fold (0.22 log units) below the measured one; the range from low to high includes it.
By their numbers in this assay, from the lowest: compounds 2, 1 and 3 (each within the scatter of the next).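

Among the compounds shown here, until now no measured pair isolated a single change, and this one does: the fact that compounds 2 and 3 differ only in the configuration as drawn. In this assay, drawing the saturated ring carbon as S rather than R amounts to a 1.8-fold higher number from compound 2 to compound 3 (0.24 log units; within the scatter), so half-life does not separate the two forms. For the compounds shown here, at this one stereocentre, with this one substituent, the configuration therefore carries no resolved difference, although a single pair gives only one reading and cannot show whether a small real difference lies hidden inside the scatter.

As far as these compounds go, whether the same holds at any of the other stereo elements, or with a different group on this carbon, such as a carboxylic acid or a primary amine in either configuration, stays open. The pair also speaks only to this assay, so any difference between the R and S forms in other read-outs cannot be judged from these compounds.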